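The source may report more compounds than this note shows. Statements on the series, on what has been measured and on what is new or still open speak of the compounds shown alone.

Measured so far in a functional assay on MCF7 cells (Homo sapiens) for inhibition, read by MTT assay; a lower number here means a stronger inhibitor, a higher number a weaker inhibitor:
- compound 1 `O=C(CCCCCCC(=O)Nc1nnc(-c2ccco2)s1)NO` gives 880 nM
- compound 2 `Cc1ccc(-c2nnc(NC(=O)CCCCCCC(=O)NO)s2)o1` gives 880 nM
- compound 3 `CC(C)=CCC/C(C)=C/CC/C(C)=C/CSc1ccccc1C(=O)NCCC(=O)NO` gives 4930 nM

Compound 2 shares the lowest of the three numbers with compound 1 . Compound 3 has the highest number at 4930 nM, against 880 nM for compound 2 . Going by the values given here, no single-place step links compound 3 to the others, so it offers no guide here.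

The next compound is compound 4 `Cc1ccc(-c2nnc(NC(=O)CCCCCCC(=O)NO)s2)s1`. It keeps the chain and core of compound 2 and changes one group: 5-methylthiophen-2-yl in place of 5-methylfuran-2-yl on an aromatic carbon. This is 5-methylthiophen-2-yl in place of 5-methylfuran-2-yl on an aromatic carbon of a five-membered aromatic ring with 2 nitrogen and 1 sulfur.

Among the compounds with values here, only one measured step touches this group: no change at the digits printed from compound 1 to compound 2 (within the scatter). That step is a methyl in place of hydrogen on an aromatic carbon, and it leaves the ring itself unchanged. Within the data shown here, no measured pair shows the exchange made here, so its size rests on indirect evidence alone. With that one step showing no change, no shift beyond the scatter is expected in this assay, in either direction. The expected step is a 1.0-fold higher number from compound 2 to compound 4 (0.01 log units; within the scatter). In this assay the estimated value for compound 4 is 900 nM, with an expected range of 350 nM to 2300 nM.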

Compound 4, half-maximal inhibitory concentration: 880 nM
Beside the measured number, compound 4's estimate is 1.0-fold (0.01 log units) above it, and the stated range covers the measured number.
By their numbers in this assay, from the lowest: compounds 1, 2 and 4 (each within the scatter of the next); then compound 3.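

In this assay, going by these compounds alone, compounds 1, 2 and 4 give the first direct reading of a change to the ring itself at this place on the core, as earlier data covered only a methyl on that ring. Exchanging 5-methylfuran-2-yl for 5-methylthiophen-2-yl gives no change at the digits printed from compound 2 to compound 4 (within the scatter), so ring oxygen and ring sulfur cannot be told apart here on a methylated ring. The combined exchange, 5-methylthiophen-2-yl in place of furan-2-yl, gives no change at the digits printed from compound 1 to compound 4 (within the scatter), so the added methyl and the exchanged ring atom together also leave the number within the scatter, and no measurement available here accounts for this flat response.

From the compounds shown here alone, all three compounds in this subset carry a five-membered aromatic ring with 1 hetero atom at this place, so it remains open whether a phenyl ring, or a ring carrying an amine or a carboxylic acid, would move the number beyond the scatter. Within the data shown here, compound 3 is linked to this subset by no single-place step, so the effect of a longer or shorter chain on the shared core also remains open.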